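A few compounds are considered here, and "the series" means these few. Any claim that something is new, unique, unknown or untested is made for them only; others in the source may bear on it.

Measured so far, in a functional assay on SMMC-7721 cells (Homo sapiens) for inhibition, read by MTT assay, with a stated time of 72 h, tested at 10 uM; a higher number here means a stronger effect of the compound at the concentration tested, a lower number a weaker effect:
- compound 1, `Clc1ccc(COc2ccccc2/C=C/C(/C=C/c2ccccn2)=N/Oc2ncnc3cc(Cl)ccc23)c(Cl)c1`, gives 91.8%
- compound 2, `Clc1ccc2c(O/N=C(/C=C/c3ccc(OCc4ccccc4Cl)cc3)\C=C\c3ccccn3)ncnc2c1`, gives 84.7%

Compound 2 and compound 1 lie within the usual scatter of each other, so the two numbers show no real gap between them. Compound 3, `Clc1ccc(COc2ccc(/C=C/C(/C=C/c3ccccn3)=N/Oc3ncnc4cc(Cl)ccc34)cc2)cc1`, has not yet been measured. It differs from compound 2 in one place: 4-chlorophenyl in place of 2-chlorophenyl on a saturated chain carbon bound to an oxygen on an aromatic ring. For the measured compounds named here, no measured pair shows the effect of such a change here, so the expected step is none beyond the scatter, in either direction. In this assay compound 3 is expected to give 85%, within 70% to 95%. The expected step of a number 0.3 percentage points higher from compound 2 to compound 3 (within the scatter) is therefore small.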

Compound 3, a percentage reported as inhibition, at one concentration (the size of the read-out at that concentration, not a potency): 88.1%
Compound 3: middle estimate off by 3.1 percentage points, on the low side; low and high end bracket the measured number.
By their numbers in this assay, from the lowest: compounds 2, 3 and 1 (each within the scatter of the next).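

In this assay, putting 4-chlorophenyl in place of 2-chlorophenyl on a saturated chain carbon bound to an oxygen on an aromatic ring gives a number 3.4 percentage points higher from compound 2 to compound 3 (within the scatter). For these two placements, then, the position of the chlorine on this ring makes no measurable difference to the read-out. No measurement here offers a reason for this result.

Going by these compounds, it remains open whether a phenyl ring carrying an amine or a carboxylic acid instead of the chlorine would shift the number. A reading at one concentration also says nothing about potency.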